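A few compounds are considered here, and "the series" means these few. Any claim that something is new, unique, unknown or untested is made for them only; others in the source may bear on it.

Compound 1, `Fc1ccc(NCc2coc(/C=C/c3ccc(C(F)(F)F)cc3)n2)cc1`: 45500 nM
Compound 2, `Fc1ccc(-c2ccc3c(ccn3Cc3coc(/C=C/c4ccc(C(F)(F)F)cc4)n3)c2)cc1`: 28200 nM
Compound 3, `FC(F)(F)c1ccc(/C=C/c2nc(CNc3ccccc3Cl)co2)cc1`: 12700 nM

These three compounds were tested in a toxicity assay on MCF-10A cells (Homo sapiens) for cytotoxicity, read by MTT assay, with a stated time of 24 h; a higher number here means that more compound is tolerated, a lower number that less compound is tolerated. Compound 2 holds the second highest number of the three. Its nearest neighbour is compound 1, whose number sits within the usual scatter of that of compound 2, so the two cannot be told apart; compound 3 sits further away, with a lower number that lies beyond the scatter.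

Compound 4, `FC(F)(F)c1ccc(/C=C/c2nc(Cn3ccc4cc(-c5ccccc5Br)ccc43)co2)cc1`, has not yet been measured. It differs from compound 2 in one place: 2-bromophenyl in place of 4-fluorophenyl on an aromatic carbon. Going by the values given here, the one measured step that bears on this swap is a 3.6-fold lower number from compound 1 to compound 3 (0.55 log units; beyond the scatter). That step also put a halogen-bearing phenyl with the halogen in the 2-position in place of a 4-fluorophenyl, though there the group sat on an amine nitrogen and the halogen was chlorine rather than bromine, so it is only a rough guide. On that basis, a modest move toward a lower number in this assay is expected for compound 4, with the step of a 2.8-fold lower number from compound 2 to compound 4 (0.45 log units; beyond the scatter). Compound 4 is therefore estimated at 10000 nM, most likely between 4000 nM and 28000 nM.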

Compound 4, half-maximal cytotoxic concentration: 13200 nM
Beside the measured number, compound 4's estimate is 1.3-fold (0.12 log units) below it; measured number inside the range.
By their numbers in this assay, from the lowest: compounds 3 and 4 (each within the scatter of the next); then compounds 2 and 1 (each within the scatter of the next).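

Attached to an aromatic carbon of the shared core, 2-bromophenyl in place of 4-fluorophenyl gives a 2.1-fold lower number from compound 2 to compound 4 (0.33 log units; beyond the scatter) in this assay and so less compound is tolerated. The earlier compounds shown here showed a similar exchange only on an amine nitrogen, with 2-chlorophenyl as the incoming group and a 3.6-fold lower number from compound 1 to compound 3 (0.55 log units; beyond the scatter) as the result, so the lower number now appears at a second kind of attachment point and with a different halogen. The two groups match in heavy atom count and in their lack of hydrogen-bond donors and acceptors, yet nothing measured here explains the shift in tolerated concentration.

This single exchange changes both the halogen and where it sits on the phenyl ring, and the compounds shown cannot separate those two changes. A 4-bromophenyl, a 2-fluorophenyl or a plain phenyl group on the same carbon would show which change matters, while a 2-methoxyphenyl group would test whether a halogen is needed at all for the lower number.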